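Acetylation of the ring amine across two cores

The source may hold more compounds than are shown below. What is called first, only, known or untested is meant among the compounds shown, and "the series" means these compounds.

Compound 1 `Nc1cc(OCc2ccccc2)nc(SCc2ccccc2)n1` and compound 2 `CC(=O)Nc1cc(OCc2ccccc2)nc(SCc2ccccc2)n1` share a core; compound 3 `Nc1cc(=O)n(Cc2ccccc2)c(SCc2ccccc2)n1` and compound 4 `CC(=O)Nc1cc(=O)n(Cc2ccccc2)c(SCc2ccccc2)n1` share another, and the difference between the two cores is not broken down here. In a functional assay on A549 cells (Homo sapiens) for antiproliferative activity, read by MTT assay, with a stated time of 72 h (on this read-out lower numbers stand for stronger inhibition of growth and higher numbers for weaker inhibition of growth), compound 1 gives 46200 nM. In this assay compound 2 gives 35200 nM, so the change acetyl in place of hydrogen on a nitrogen on an aromatic ring produced a 1.3-fold lower number from compound 1 to compound 2 (0.12 log units; within the scatter). For compound 3, this assay reports only a limit, > 100000 nM, which is the limit of > 100000 nM in this assay, at which 1 of the 3 values shown sits. The same change, (acetyl in place of hydrogen on a nitrogen on an aromatic ring), takes compound 3 to compound 4. Since the step of a 1.3-fold lower number from compound 1 to compound 2 (0.12 log units; within the scatter) was within the scatter, the step from compound 3 to compound 4 is expected to be small as well, a step that the limit leaves unreadable from compound 3 to compound 4, and compound 4 is therefore estimated to remain near the limit, at about 120000 nM, between 50000 nM and 300000 nM.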

Compound 4, concentration for 50% growth inhibition: 50400 nM
Compound 4: middle estimate off by 2.4-fold (0.38 log units), on the high side, and the stated range covers the measured number.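

In this assay compound 3 gives > 100000 nM, a limit of the assay and not a number. On this core, amino to acetamido can be read only as a floor, an at least 1.9-fold lower number from compound 3 to compound 4 (0.29 log units; that floor lies within the scatter). Neither core gives a higher number with the acetyl group, but this does not establish that the size of the step carries from one core to the other: the same change on two cores in this assay, a 1.3-fold lower number (0.12 log units; within the scatter) from compound 1 to compound 2 and an at least 1.9-fold lower number (0.29 log units; that floor lies within the scatter) from compound 3 to compound 4; the limit leaves it open whether they differ

The compounds shown leave open whether another group on that nitrogen, such as a longer acyl chain, a methyl group or a sulfonamide, would move the number beyond the scatter on either core. They also leave open whether a carboxylic acid on the acyl chain would do so.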